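A few compounds are considered here, and "the series" means these few. Any claim that something is new, unique, unknown or untested is made for them only; others in the source may bear on it.

Compounds in an ADME assay on HEK293 cells (Homo sapiens) for inhibition, read by MTT assay, with a stated time of 2 days; a higher number here means a weaker inhibitor, a lower number a stronger inhibitor:
- compound 1 `Oc1ccc(/C=C/c2cccc(O)c2)cc1`: 1.1 ug/mL
- compound 2 `Nc1cccc(/C=C/c2ccc(O)cc2)c1`: 7 ug/mL
- compound 3 `Nc1ccc(/C=C/c2cccc(O)c2)cc1`: not yet measured

Compound 1 has the lower of the two measured numbers, which makes it the stronger inhibitor of the pair. Compound 3 replaces one hydroxy of compound 1 with amino on an aromatic carbon, para to a group of 9 heavy atoms: amino in place of hydroxy on an aromatic carbon. Among the measured compounds shown here, only one measured step bears on this, the same swap made at the other hydroxy, and it is modest: a 6.4-fold higher number from compound 1 to compound 2 (0.80 log units; beyond the scatter). Going by that step, a higher number of similar or somewhat smaller size is expected in this assay, though a single step is thin evidence. The estimated step is a 4.5-fold higher number from compound 1 to compound 3 (0.66 log units; beyond the scatter). The estimated value for compound 3 is 5 ug/mL, with an expected range of 1.5 ug/mL to 15 ug/mL.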

Compound 3, half-maximal inhibitory concentration: 25 ug/mL
Compound 3: middle estimate off by 5.0-fold (0.70 log units), on the low side; the measured number lies above the stated range.
By their numbers in this assay, from the lowest: compound 1; then compound 2; then compound 3.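

In this assay, putting amino in place of hydroxy on the aromatic carbon para to a group of 9 heavy atoms gives a large step (a 23-fold higher number from compound 1 to compound 3 (1.36 log units; beyond the scatter)). The same swap at the other hydroxy gave a smaller one (a 6.4-fold higher number from compound 1 to compound 2 (0.80 log units; beyond the scatter)), so in these compounds the size of the change depends on which hydroxy is replaced. Nothing available explains this difference.

From the compounds shown here alone, whether the weaker inhibition comes from losing the hydroxy or from gaining the amino remains open. A methoxy group or a plain hydrogen at this position could help separate the two.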